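This account rests on a few compounds, and the source may have more. Where it says the series, first, only, none or still open, it means among the compounds named here.

Compound 1 `Cc1noc(C)c1-c1ccc2c(c1)C(c1ccccc1)N(Cc1nnc(-c3ccccc3)o1)C(=O)N2C` and compound 2 `Cc1nc(-c2ccccc2)sc1CN1C(=O)N(C)c2ccc(-c3c(C)noc3C)cc2C1c1ccccc1` share one core and differ only in the group hanging from a saturated chain carbon bound to an amide-type nitrogen in a ring. In an ADME assay on MCF-10A cells (Homo sapiens) for inhibition, read by MTT assay, with a stated time of 48 h, tested at 2 uM (on this read-out higher numbers stand for more inhibition at the one concentration tested (going by the name of the read-out) and lower numbers for less inhibition), compound 1 gives 12.4%, and compound 2 gives 4.9%. The step of a number 7.5 percentage points lower from compound 1 to compound 2 (within the scatter) is within the scatter, so the two cannot be told apart on these numbers; compound 2 simply sits at one end of the pair.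

Compound 3 `Cc1noc(C)c1-c1ccc2c(c1)C(c1ccccc1)N(Cc1nnc(-c3ccccc3)s1)C(=O)N2C` is not yet measured. It differs from compound 2 by 5-phenyl-1,3,4-thiadiazol-2-yl in place of 4-methyl-2-phenyl-1,3-thiazol-5-yl on a saturated chain carbon bound to an amide-type nitrogen in a ring. Among the compounds with values here, the only measured step at this position is the one from compound 1 to compound 2, and it stayed within the scatter. A change of the ring at the same place is therefore expected to give no step beyond the scatter in this assay.

Compound 3 is thus estimated at 8%, with a range from 0% to 20%. The expected step is a number 3.1 percentage points higher from compound 2 to compound 3 (within the scatter), judged to lie within the scatter.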

Compound 3, a percentage reported as inhibition, at one concentration (the size of the read-out at that concentration, not a potency): 3.3%
The estimate for compound 3 lay 4.7 percentage points above the measured number; the range from low to high includes it.
By their numbers in this assay, from the lowest: compounds 3, 2 and 1 (each within the scatter of the next).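

Putting 5-phenyl-1,3,4-thiadiazol-2-yl in place of 4-methyl-2-phenyl-1,3-thiazol-5-yl gives a number 1.6 percentage points lower from compound 2 to compound 3 (within the scatter) in this assay, so a third ring at this place can still not be told apart from the second. The new pair of compound 1 and compound 3 is closer still, since 5-phenyl-1,3,4-oxadiazol-2-yl and 5-phenyl-1,3,4-thiadiazol-2-yl both hold a phenyl on a five-membered aromatic ring with 3 hetero atoms, and it gives a number 9.1 percentage points lower from compound 1 to compound 3 (within the scatter), so this exchange also leaves the number inside the scatter. Nothing at hand offers an explanation for these readings.

From the compounds shown here alone, all three groups carry a phenyl on a five-membered aromatic ring, so an amine, a carboxylic acid or a longer alkyl chain at this place remains open. Whether any group here can move the number beyond the scatter also remains unanswered.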